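Removing the methoxy from the aryl amide of compound 1

The compounds below may be only part of what the source reports. "The series", "measured", "known", "first", "only" and "open" are said of these compounds alone.

Compound 1 `COc1cccc(N2C(=O)COc3ccc(-c4cnc(Cl)c(NS(=O)(=O)c5ccc(F)cc5)c4)cc32)c1` gives 32700 nM in a functional assay on A549 cells (Homo sapiens) for antiproliferative activity, read by MTT assay, with a stated time of 72 h (on this read-out lower numbers stand for stronger inhibition and higher numbers for weaker inhibition), the highest of the two numbers shown. Its nearest neighbour is compound 2 `COc1cccc(N2C(=O)COc3ccc(-c4cnc(OC)c(NS(=O)(=O)c5ccc(F)cc5)c4)cc32)c1` at 11200 nM, reached by a 2.9-fold lower number from compound 1 to compound 2 (0.47 log units; beyond the scatter), methoxy in place of chloro on an aromatic carbon. Compound 3 `COc1cccc(N2C(=O)COc3ccc(-c4cnc5ccccc5c4)cc32)c1` gives only a limit of the assay, > 40000 nM. Part of the series therefore sits at the limit of > 40000 nM in this assay, at which 1 of the 3 values shown sits.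

Compound 4 `O=C1COc2ccc(-c3cnc(Cl)c(NS(=O)(=O)c4ccc(F)cc4)c3)cc2N1c1ccccc1` differs from compound 1 by hydrogen in place of methoxy on an aromatic carbon. For the measured compounds named here, no measured step touches this place, and the one step measured, a 2.9-fold lower number from compound 1 to compound 2 (0.47 log units; beyond the scatter), sits on another ring. For compound 4 no step beyond the scatter is expected, so its estimate in this assay is 33000 nM, between 14000 nM and 80000 nM. That expectation means a 1.0-fold higher number from compound 1 to compound 4 (0.00 log units; within the scatter).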

Compound 4, half-maximal inhibitory concentration: 14700 nM
Beside the measured number, compound 4's estimate is 2.2-fold (0.35 log units) above it; low and high end bracket the measured number.
By their numbers in this assay, from the lowest: compounds 2 and 4 (each within the scatter of the next); then compound 1. At a limit, above all of these: compound 3.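

Hydrogen in place of methoxy, on the six-membered aromatic ring of carbon only, gives a 2.2-fold lower number from compound 1 to compound 4 (0.35 log units; beyond the scatter) in this assay, so this ring responds to change and the methoxy is not required for the activity of compound 1. The step is modest, and nothing shown accounts for it.

On these data alone, it remains open whether the same change holds with the methoxy of compound 2 in place of chloro. Also open, as far as these compounds go, is how an amine, a hydroxyl or a longer alkoxy chain would read at this place.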